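The compounds below may be only part of what the source reports. "The series", "measured", "known", "first", "only" and "open" are said of these compounds alone.

Measured so far:
compound 1 `O=c1nc2oc(C3CC3)c(C#CC3CC3)c2cn1Cc1cn(Cc2ccccc2)nn1` — 290 nM
compound 2 `O=c1nc2oc(CCCCl)c(C#CCCCCl)c2cn1Cc1cn(-c2ccc(Cl)cc2)nn1` — > 100000 nM
compound 3 `CCCCCc1ccc(C#Cc2c(-c3ccc(CCCCC)cc3)oc3nc(=O)n(Cc4cn(Cc5ccccc5)nn4)cc23)cc1` — 2650 nM

Working notes on the series, read in an ADME assay on WI-38 cells (Homo sapiens) for antiproliferative activity, read by MTT assay, with a stated time of 72 h; on this read-out lower numbers stand for stronger inhibition and higher numbers for weaker inhibition. Compound 3 `CCCCCc1ccc(C#Cc2c(-c3ccc(CCCCC)cc3)oc3nc(=O)n(Cc4cn(Cc5ccccc5)nn4)cc23)cc1` stands at the higher of the two numbers obtained, with compound 1 `O=c1nc2oc(C3CC3)c(C#CC3CC3)c2cn1Cc1cn(Cc2ccccc2)nn1` the nearest point below it, and the gap between them lies beyond the scatter. The value of compound 2 `O=c1nc2oc(CCCCl)c(C#CCCCCl)c2cn1Cc1cn(-c2ccc(Cl)cc2)nn1` is a limit of the assay, not a number; it sits at the limit of > 100000 nM in this assay, at which 1 of the 3 values shown sits. For the measured compounds named here, no two measured compounds differ in a single place, so no measured step is available here.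

Compound 4 `CCCCCc1ccc(C#Cc2c(-c3ccc(CCCCC)cc3)oc3nc(=O)n(Cc4cn(-c5ccccc5F)nn4)cc23)cc1` is the one still to be measured. It differs from compound 3 in one place: 2-fluorophenyl in place of benzyl on an aromatic nitrogen. Going by the values given here, the groups that leave and enter match in size and in ring count, and nothing among the measured compounds shows what such a change does in this assay.

The step from compound 3 to compound 4 is expected to stay small, with no clear direction beyond the scatter: a 1.3-fold higher number from compound 3 to compound 4 (0.12 log units; within the scatter). Compound 4 is accordingly estimated at 3500 nM, within 1200 nM to 12000 nM.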

Compound 4, half-maximal inhibitory concentration: 7340 nM
For compound 4 the middle estimate is 2.1-fold (0.32 log units) below the measured one; measured number inside the range.
By their numbers in this assay, from the lowest: compound 1; then compound 3; then compound 4. At a limit, above all of these: compound 2.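

For the compounds shown here, this is the only single-place step so far: in this assay, 2-fluorophenyl in place of benzyl on an aromatic nitrogen gives a 2.8-fold higher number from compound 3 to compound 4 (0.44 log units; beyond the scatter). The substituent on this nitrogen therefore affects the read-out, and this change goes towards weaker inhibition, although the two groups match in heavy-atom count and ring count. Nothing shown gives a cause for this step.

On these data alone, it remains open whether the step follows from the fluorine or from attaching the ring directly to the nitrogen; unsubstituted phenyl and 2-fluorobenzyl on the same nitrogen would separate the two. As far as these compounds go, it is also open whether the same change has a similar effect when the cyclopropyl groups of compound 1 replace the pentylphenyl groups of compound 3.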